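The source may report more compounds than this note shows. Statements on the series, on what has been measured and on what is new or still open speak of the compounds shown alone.

For the measured compounds named here, compound 1 `C=C(Br)C(=O)Nc1cccc(-c2cn3nc(-c4ccc(OCC)cc4)sc3n2)c1` is one of two compounds so far measured in a functional assay on CCRF-CEM cells (Homo sapiens) for inhibition, read by cell counting, with a stated time of 3 days; a higher number here means a weaker inhibitor, a lower number a stronger inhibitor. In this assay compound 1 gives 1400 nM, the lowest of the two numbers. The other, compound 2 `Nc1cccc(-c2cn3c(-c4ccccc4)csc3n2)c1`, gives 29000 nM in this assay, a value that lies beyond the usual scatter from that of compound 1; since the two structures differ in more than one place, nothing is said here about a single step between them. Compound 3 `C=C(Br)C(=O)Nc1cccc(-c2cn3nc(-c4ccc(OC)cc4)sc3n2)c1` has not yet been measured. It differs from compound 1 by one change: hydrogen in place of methyl on a saturated chain carbon bound to an oxygen on an aromatic ring Cut one bond further out, the change reads as ethoxy to methoxy, ethyl to methyl, 4-ethoxyphenyl to 4-methoxyphenyl; the shared core is otherwise unchanged. Going by the values given here, no measured pair shows what this change does in this assay. On the evidence of compound 1 alone, the step of a 1.1-fold higher number from compound 1 to compound 3 (0.03 log units; within the scatter) is expected to be small, in neither direction beyond the scatter. Compound 3 is therefore estimated to give 1500 nM in this assay, with a range of 600 nM to 4000 nM.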

Compound 3, half-maximal inhibitory concentration: 1200 nM
Compound 3: middle estimate off by 1.3-fold (0.10 log units), on the high side; low and high end bracket the measured number.
By their numbers in this assay, from the lowest: compounds 3 and 1 (each within the scatter of the next); then compound 2.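

In this assay, for the compounds shown here, the replacement of ethoxy by methoxy gives a 1.2-fold lower number from compound 1 to compound 3 (0.07 log units; within the scatter), the first measured step at this position. It shows that, on this shared core, taking away the methyl on a saturated chain carbon bound to an oxygen on an aromatic ring, a change of one carbon, does not move the number beyond the scatter, so the 4-ethoxyphenyl and 4-methoxyphenyl compounds cannot be told apart here. The data offer no measured property that bears on this result.

Going by these compounds, this single pair covers only ethyl to methyl, so it remains open whether a longer chain such as butoxy, or a hydroxyl or a carboxylic acid in place of the alkoxy group, would give a number beyond the scatter from that of compound 1. It is also open whether the same change from ethoxy to methoxy would give a step of similar size on a different core, such as that of compound 2, for which no single-change partner is shown.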